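Thiazole in place of trifluoromethoxyphenyl on the amide carbonyl

This account rests on a few compounds, and the source may have more. Where it says the series, first, only, none or still open, it means among the compounds named here.

Going by the values given here, compound 3 `O=C(COc1ccc2c(=O)ccoc2c1)Nc1cccc(NC(=O)c2ccc(OC(F)(F)F)cc2)c1` gives 869 nM in an assay on isolated protein for inhibition of Rho-associated protein kinase 1 (Homo sapiens), read by scintillation counting, radiometric assay and 33P incorporation, with a stated time of 40 min, in the presence of a further agent that is not named here (on this read-out higher numbers stand for weaker inhibition and lower numbers for stronger inhibition), and stands highest of the three numbers measured so far. Compound 1 `COc1ccc(C(=O)Nc2cccc(NC(=O)COc3ccc4c(=O)ccoc4c3)c2)cc1` gives 18 nM in this assay, and compound 2 `CCOc1ccc(C(=O)Nc2cccc(NC(=O)COc3ccc4c(=O)ccoc4c3)c2)cc1` gives 17 nM. The step of a 1.1-fold lower number from compound 1 to compound 2 (0.02 log units; within the scatter) lies within the scatter, whereas the steps of a 48-fold higher number from compound 1 to compound 3 (1.68 log units; beyond the scatter) and a 51-fold higher number from compound 2 to compound 3 (1.71 log units; beyond the scatter) are large and beyond it.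

Compound 4 `O=C(COc1ccc2c(=O)ccoc2c1)Nc1cccc(NC(=O)c2cnc(C(F)(F)F)s2)c1` is not yet measured. It differs from compound 3 by 2-(trifluoromethyl)-1,3-thiazol-5-yl in place of 4-(trifluoromethoxy)phenyl on a carbonyl carbon. Among the compounds with values here, none of the measured steps changes the ring on the carbonyl carbon: all three alter only the group on the oxygen of that ring, so they do not bear directly on this change. The trifluoromethyl group is retained in compound 4, now on the thiazole rather than on an oxygen. Within the data shown here, with no measured step of this kind, no direction is set by the data; a step in this assay of the size a 1.2-fold lower number from compound 3 to compound 4 (0.09 log units; within the scatter) is expected, not beyond the scatter, with wide uncertainty either way. Compound 4 is therefore expected to give 700 nM in this assay, with a range from 150 nM to 3000 nM.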

Compound 4, half-maximal inhibitory concentration: 160 nM
Estimate against measurement, compound 4: 4.4-fold (0.64 log units) above, within the range that was stated.
By their numbers in this assay, from the lowest: compounds 2 and 1 (each within the scatter of the next); then compound 4; then compound 3.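

Going by these compounds alone, the ring on the carbonyl carbon can itself be exchanged with a measurable effect in this assay: replacing 4-(trifluoromethoxy)phenyl with 2-(trifluoromethyl)-1,3-thiazol-5-yl gives a 5.4-fold lower number from compound 3 to compound 4 (0.73 log units; beyond the scatter), whereas the earlier steps changed only the group on the ring oxygen. The thiazole does not reach the level of either alkoxyphenyl compound, with an 8.9-fold higher number from compound 1 to compound 4 (0.95 log units; beyond the scatter) and a 9.4-fold higher number from compound 2 to compound 4 (0.97 log units; beyond the scatter), so a trifluoromethyl-bearing group on this carbonyl carbon can stand much closer to those two compounds than compound 3 does. Nothing available here explains why the thiazole and phenyl groups differ in this way.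

The compounds shown cannot separate the contribution of the thiazole ring from that of moving the trifluoromethyl group off the oxygen, since the methoxy and ethoxy groups appear only on the phenyl ring and trifluoromethyl only in these two forms. From the compounds shown here alone, it also remains open how this assay would respond to a methoxy group, an ethoxy group, an amine or a carboxylic acid in place of trifluoromethyl on the thiazole.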